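Replacing the Benzyl Phenyl with Ethyl at the Pyrazole Substituent

The source may hold more compounds than are shown below. What is called first, only, known or untested is meant among the compounds shown, and "the series" means these compounds.

Three compounds share one core and differ only in the group attached to a single carbon on the core. Compound 1 `Cc1cc(-c2ccc(F)cc2)n(Cc2ccc(C(=O)NO)cc2)n1` carries a methyl there, and in an assay on cells for inhibition of protein deacetylase HDAC6 (Homo sapiens), read by fluorescence, with stated times of 15 min and 60 min (on this read-out lower numbers stand for stronger inhibition and higher numbers for weaker inhibition), compound 1 gives 20 nM. Compound 3 `CCc1cc(-c2ccc(F)cc2)nn1Cc1ccc(C(=O)NO)cc1` carries an ethyl, and in this assay compound 3 gives 35 nM. Compound 2 `O=C(NO)c1ccc(Cn2nc(Cc3ccccc3)cc2-c2ccc(F)cc2)cc1` carries a benzyl, and in this assay compound 2 gives 420 nM, the highest of the three numbers; compound 3 stands nearest to it and compound 1 furthest.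

Compound 4 `CCCc1cc(-c2ccc(F)cc2)n(Cc2ccc(C(=O)NO)cc2)n1` is made from compound 2 by the change (ethyl in place of phenyl on a saturated chain carbon bound to an aromatic carbon). Among the measured compounds shown here, one measured step bears on this: a 21-fold higher number from compound 1 to compound 2 (1.32 log units; beyond the scatter), which is the reverse kind of change, adding a phenyl on that same carbon. Removing the phenyl and leaving a shorter chain is therefore expected to move the number back down, by a step of roughly a 6.0-fold lower number from compound 2 to compound 4 (0.78 log units; beyond the scatter), though a propyl is longer than the methyl of compound 1 or the ethyl of compound 3, so the full return is not expected. In this assay compound 4 is estimated at 70 nM, with a likely range from 25 nM to 200 nM.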

Compound 4, half-maximal inhibitory concentration: 167 nM
Compound 4: middle estimate off by 2.4-fold (0.38 log units), on the low side; the range from low to high includes it.
By their numbers in this assay, from the lowest: compounds 1 and 3 (each within the scatter of the next); then compound 4; then compound 2.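

The phenyl accounts for only part of the rise seen with the benzyl group: removing it and leaving a propyl gives a 2.5-fold lower number from compound 2 to compound 4 (0.40 log units; beyond the scatter) in this assay and recovers little of the ground lost. Even without a ring, the chain carries a clear cost, as the propyl shows an 8.4-fold higher number from compound 1 to compound 4 (0.92 log units; beyond the scatter) in the same assay. Across compounds 1, 4 and 2, the number therefore rises in step as the group on this carbon goes from methyl to propyl to benzyl, and nothing measured here gives a reason for either step.

Three groups cannot separate the effect of chain length from that of a ring, so a butyl or a cyclohexylmethyl group would be informative here. Going by these compounds, how an amine or a carboxylic acid at the end of the propyl chain would behave also remains open.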